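A few compounds are considered here, and "the series" means these few. Any claim that something is new, unique, unknown or untested is made for them only; others in the source may bear on it.

Of the compounds shown here, three have been tested so far in a functional assay on V79 cells (Cricetulus griseus) for cytotoxicity, read by colony formation (on this read-out higher numbers stand for weaker inhibition and lower numbers for stronger inhibition), a read-out in which a smaller number means the compound stops the cells from forming colonies at a lower concentration. Compound 1, with the structure `CC1(CN)CCN(c2cc3c(cc2F)c(=O)c(C(=O)O)cn3C2CC2)C1`, gives 23 ug/mL. Compound 2, `CC1(CN)CCN(c2c(F)cc3c(=O)c(C(=O)O)cn(C4CC4)c3c2F)C1`, gives 8 ug/mL. Compound 3, `NC1CCN(c2cc3c(cc2F)c(=O)c(C(=O)O)cn3C2CC2)CC1`, gives 230 ug/mL, the highest of the three numbers.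

Two comparisons are possible. Going from compound 1 to compound 2 the change is fluoro in place of hydrogen on an aromatic carbon, and this assay shows a 2.9-fold lower number from compound 1 to compound 2 (0.46 log units; beyond the scatter). Going from compound 1 to compound 3 the change is 4-aminopiperidin-1-yl in place of 3-(aminomethyl)-3-methylpyrrolidin-1-yl on an aromatic carbon, and this assay shows a 10-fold higher number from compound 1 to compound 3 (1.00 log units; beyond the scatter).

Compound 4, `NC1CCN(c2c(F)cc3c(=O)c(C(=O)O)cn(C4CC4)c3c2F)CC1`, has not yet been measured. It stands to compound 3 as compound 2 stands to compound 1: the change is fluoro in place of hydrogen on an aromatic carbon. The surroundings are not identical, since here the new fluoro sits ortho to a 4-aminopiperidin-1-yl group rather than ortho to a 3-(aminomethyl)-3-methylpyrrolidin-1-yl group, so this is the same kind of change, not the same change.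

Within this assay the step from compound 3 to compound 4 is expected to be a 2.6-fold lower number from compound 3 to compound 4 (0.41 log units; beyond the scatter), a guess that rests on the one precedent because a 2.9-fold lower number from compound 1 to compound 2 (0.46 log units; beyond the scatter), while allowing that the different neighbouring group may alter the outcome. For compound 4 the estimated value is 90 ug/mL, with a plausible range from 35 ug/mL to 230 ug/mL.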

Compound 4, half-maximal inhibitory concentration: 23 ug/mL
Estimate against measurement, compound 4: 3.9-fold (0.59 log units) above; measured number below the stated range.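

In this assay the fluoro moves the number the same way on both cores, with a 10-fold lower number from compound 3 to compound 4 (1.00 log units; beyond the scatter), but the size of the step does not carry over from one core to the other: the same change on two cores in this assay, a 2.9-fold lower number (0.46 log units; beyond the scatter) from compound 1 to compound 2 and a 10-fold lower number (1.00 log units; beyond the scatter) from compound 3 to compound 4, 3.5-fold (0.54 log units) apart, beyond the scatter of two such steps. The swap of 3-(aminomethyl)-3-methylpyrrolidin-1-yl for 4-aminopiperidin-1-yl also keeps its direction once the extra fluoro is present, with a 2.9-fold higher number from compound 2 to compound 4 (0.46 log units; beyond the scatter), and its size again differs from the earlier step: the same change on two cores in this assay, a 10-fold higher number (1.00 log units; beyond the scatter) from compound 1 to compound 3 and a 2.9-fold higher number (0.46 log units; beyond the scatter) from compound 2 to compound 4, 3.5-fold (0.54 log units) apart, beyond the scatter of two such steps. So in these four compounds the direction of each change held while its size depended on the rest of the molecule, which means the two changes do not simply add up; two pairs cannot show that the direction would hold on further cores, and they do not explain why the sizes differ.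

The compounds shown leave open whether the fluoro step would be large or small with other amines in the same place, such as a piperazine or a 3-aminopyrrolidin-1-yl group. As far as these compounds go, whether a chloro or a methoxy group in place of the new fluoro would shift the number in the same direction also remains open.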